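Chloro for trifluoromethyl on the triazole-linked aryl ring

The source may report more compounds than this note shows. Statements on the series, on what has been measured and on what is new or still open speak of the compounds shown alone.

Measured so far:
compound 1, `C=C1C[C@]23C[C@@]1(O)CC[C@H]2c1ccc(O)c(C)c1[C@@H]3Cn1cc(-c2ccc(C(F)(F)F)cc2)nn1` — > 20000 nM
compound 2, `C=C1C[C@]23C[C@@]1(O)CC[C@H]2c1cc(Br)c(O)c(C)c1[C@@H]3Cn1cc(-c2ccc(C(F)(F)F)cc2)nn1` — 12800 nM
compound 3, `C=C1C[C@]23C[C@@]1(O)CC[C@H]2c1ccc(OS(=O)(=O)c2ccc(C)cc2)c(C)c1[C@@H]3Cn1cc(-c2ccc(C(F)(F)F)cc2)nn1` — > 20000 nM

In a functional assay on SMMC-7721 cells (Homo sapiens) for cytotoxicity, read by MTT assay, with a stated time of 4 days (on this read-out lower numbers stand for stronger inhibition and higher numbers for weaker inhibition), compound 1 gives > 20000 nM, which is a limit of the assay and not a number. Compound 2 gives 12800 nM in this assay. Compound 3 gives > 20000 nM, again a limit rather than a number. The two measured steps both alter the phenol end of the shared core: an at least 1.5-fold lower number from compound 1 to compound 2 (0.19 log units; that floor lies within the scatter), and a step that the two limits leave unreadable from compound 1 to compound 3. The standing of compound 1 is thus known only as a limit, and the same holds for two of the three values shown (the limit of > 20000 nM in this assay, at which 2 of the 3 values shown sit).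

Compound 4, `C=C1C[C@]23C[C@@]1(O)CC[C@H]2c1ccc(O)c(C)c1[C@@H]3Cn1cc(-c2ccc(Cl)cc2)nn1`, changes the other end of the molecule: chloro in place of trifluoromethyl on an aromatic carbon. For the measured compounds named here, neither measured step touches this aryl ring, so no step bears directly on the change; both merely show that the series sits at or near the limit of this assay. With nothing to suggest a large gain, compound 4 is expected to remain close to where compound 1 stands, a step of a number no higher from compound 1 to compound 4 (the limit leaves the size open). The estimate for compound 4 in this assay is therefore 20000 nM, within a range of 8000 nM to 50000 nM.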

Compound 4, half-maximal inhibitory concentration: > 20000 nM
Compound 4: a limit, no number; the forecaster's own chance of this, stated with the estimate: 65%; the middle value lies on the limit itself.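

In this assay compound 4 gives > 20000 nM as a limit of the assay and not a number. For the compounds shown here, no step between compound 1 and compound 4 can be read, because both stand at a limit: the limit of > 20000 nM in this assay, at which 3 of the 4 values shown sit. In this assay the compounds shown leave open whether 4-(trifluoromethyl)phenyl and 4-chlorophenyl differ at all.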